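Carboxyphenyl variation in a diaryl ether acid series

A few compounds are considered here, and "the series" means these few. Any claim that something is new, unique, unknown or untested is made for them only; others in the source may bear on it.

Measured compounds in an assay on HEK293 cells for positive allosteric modulation of metabotropic glutamate receptor 3 (Rattus norvegicus), read by thallium flux, with a stated time of 2.5 min; on this read-out higher numbers stand for larger maximal responses and lower numbers for smaller maximal responses:
compound 1 `Cc1c(OCCCCOc2ccccc2C(=O)O)ccc(C(=O)CC2CCCC2)c1O` gives 32.9%
compound 2 `Cc1ccc(C(=O)O)cc1OCCCCOc1ccc(C(=O)CC(C)C)c(O)c1C` gives 29.4%
compound 3 `COc1ccc(C(=O)O)cc1OCCCCOc1ccc(C(=O)CC(C)C)c(O)c1C` gives 100%

In this assay, within the data shown here, compound 2 gives 29.4%, within the scatter of compound 1 and well below compound 3; the step of a number 70.6 percentage points higher from compound 2 to compound 3 (beyond the scatter) is the single large change in the set. Compound 4 `Cc1c(OCCCCOc2ccccc2C(=O)O)ccc(C(=O)CC(C)C)c1O` is not yet measured; from compound 2 it changes by 2-carboxyphenyl in place of 5-carboxy-2-methylphenyl on an oxygen on a saturated carbon. Among the measured compounds shown here, no measured step covers this exchange of the acid-bearing ring. Compound 1 carries the same 2-carboxyphenyl as compound 4 and differs from it only in the ketone side chain; compound 1 gives 32.9% and compound 2 gives 29.4%, both far below compound 3. No shift beyond the scatter is therefore expected in this assay for the step of a number 1.6 percentage points higher from compound 2 to compound 4 (within the scatter). Compound 4 is estimated at 31% (range 18% to 50%).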

Compound 4, largest response reached (reported as percent of maximum), in percent of the reference or control that the assay uses: 28.1%
Estimate against measurement, compound 4: 2.9 percentage points above, and the stated range covers the measured number.
By their numbers in this assay, from the lowest: compounds 4, 2 and 1 (each within the scatter of the next); then compound 3.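

In this assay, 2-carboxyphenyl in place of 5-carboxy-2-methylphenyl on an oxygen on a saturated carbon stays within the scatter (a number 1.3 percentage points lower from compound 2 to compound 4 (within the scatter)), so this exchange of the acid-bearing ring leaves the number at the low level. Isopropyl in place of cyclopentyl on the ketone side chain also stays within the scatter (a number 4.8 percentage points lower from compound 1 to compound 4 (within the scatter)). No evidence on the origin of either result is available.

Still open, going by these compounds, is whether methoxy on the 2-carboxyphenyl ring would bring the same large rise seen with compound 3. On these data alone, a tetrazole in place of the carboxylic acid, or a longer linking chain, also remains untested in these compounds.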